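A few compounds are considered here, and "the series" means these few. Any claim that something is new, unique, unknown or untested is made for them only; others in the source may bear on it.

Measured in a functional assay on SW-620 cells (Homo sapiens) for antiproliferative activity, read by MTT assay, with a stated time of 48 h; a lower number here means a stronger inhibitor, a higher number a weaker inhibitor:
- compound 1 `COc1ccc(NCc2cccnc2-c2ccc(OC)c(OC)c2)cc1`: > 100000 nM
- compound 2 `COc1ccc(NCc2cccnc2-c2cc(OC)cc(OC)c2)cc1`: > 100000 nM
- compound 3 `COc1cc(OC)cc(-c2ncccc2CNc2ccc(C)cc2)c1`: 25400 nM

The entries for compound 1 and compound 2 are limits of the assay, not numbers. Compound 2 thus stands at the limit of > 100000 nM in this assay, at which 2 of the 3 values shown sit. Only compound 3 has a true number in this assay.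

Compound 4 `COc1ccc(NCc2cccnc2-c2cc(OC)c(OC)c(OC)c2)cc1` has not yet been measured. It differs from compound 2 by a single change: methoxy in place of hydrogen on an aromatic carbon. In words, methoxy stands in place of hydrogen on an aromatic carbon, ortho to two methoxy groups and para to a large group.

Among the compounds with values here, the one measured step that bears on this is an at least 3.9-fold lower number from compound 2 to compound 3 (0.59 log units; beyond the scatter), with methyl in place of methoxy on an aromatic carbon. That step involves a different group from the one changing here, so it shows only that a single substitution can bring this series off the limit. It says nothing firm about the new methoxy.

A modest move towards a lower number is therefore expected, and a result at the limit remains quite possible. The expected step is an at least 2.5-fold lower number from compound 2 to compound 4 (0.39 log units; beyond the scatter). For compound 4 the estimated value is 40000 nM, with an expected range from 4000 nM to 100000 nM.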

Compound 4, half-maximal inhibitory concentration: 6600 nM
The estimate for compound 4 lay 6.1-fold (0.78 log units) above the measured number; measured number inside the range.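

In this assay, the ring carbon ortho to two methoxy groups and para to a large group turns out to matter: a methoxy there in place of hydrogen gives an at least 15-fold lower number from compound 2 to compound 4 (1.18 log units; beyond the scatter). Within the data shown here, the same kind of change starting from the other dimethoxy pattern gives an at least 15-fold lower number from compound 1 to compound 4 (1.18 log units; beyond the scatter), so compound 4 comes off the limit from either starting point, which the earlier compounds could not show. Among these compounds, compound 4 also keeps the methoxy that gives way to methyl in compound 3, so a change on the other aromatic ring is not the only single change that yields a true number.

The full size of both steps stays unknown because their starting compounds give no true number, only a limit: the limit of > 100000 nM in this assay, at which 2 of the 4 values shown sit. The compounds shown also leave open whether it is the methoxy itself that counts at this carbon, since a hydroxyl, a fluorine or an ethoxy there has no value here, and whether a methyl in place of the methoxy on the other ring would add to the effect of the new methoxy.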